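The source may report more compounds than this note shows. Statements on the series, on what has been measured and on what is new or still open speak of the compounds shown alone.

Working notes on the series.

For the measured compounds named here, compound 2 `O=S(=O)(c1cc(F)cc(F)c1)c1cnc2cc(F)ccc2c1-c1ccc(Cl)cc1` is the low end of the three compounds measured so far in an ADME assay on microsomes from liver (Homo sapiens) for metabolic stability, tested at 2.5 uM; a lower number here means slower removal, a higher number faster removal of the compound: compound 2 gives 0.03 mL/min, while compound 3 `O=S(=O)(c1cc(Cl)cc(Cl)c1)c1cnc2cc(F)ccc2c1-c1ccc(Cl)cc1` gives 0.13 mL/min and compound 1 `COc1cccc(-c2c(S(=O)(=O)c3ccc(OC)c(Cl)c3)cnc3cc(F)ccc23)c1` gives 1.71 mL/min. Going by the values given here, the only single-point step measured is a 4.3-fold higher number from compound 2 to compound 3 (0.64 log units; beyond the scatter). Compound 4 `COc1cccc(-c2c(S(=O)(=O)c3cc(F)cc(F)c3)cnc3cc(F)ccc23)c1` is reached from compound 2 by 3-methoxyphenyl in place of 4-chlorophenyl on an aromatic carbon. Among the compounds with values here, no measured pair isolates this change, so nothing here tells the size of the step directly. Compound 1 carries the 3-methoxyphenyl that enters, but it also differs from compound 2 at the group on the sulfonyl sulfur, so the gap between compound 2 and compound 1 cannot be assigned to one change. With compound 2 at the lowest number seen and compound 1 far higher, the step of a 5.0-fold higher number from compound 2 to compound 4 (0.70 log units; beyond the scatter) is expected to be upward, but of modest size and uncertain. Compound 4 is therefore estimated at 0.15 mL/min, with a range of 0.04 mL/min to 0.6 mL/min.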

Compound 4, intrinsic clearance in a liver preparation (reported as CLH), per the amount of preparation that the assay uses: 1.81 mL/min
Compound 4: the middle estimate sits 12-fold (1.08 log units) below what was measured; measured number outside the range, above it.
By their numbers in this assay, from the lowest: compound 2; then compound 3; then compounds 1 and 4 (each within the scatter of the next).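

For the compounds shown here, at the aromatic carbon opposite the ring nitrogen, 3-methoxyphenyl in place of 4-chlorophenyl gives the largest single-change step so far in this assay (a 60-fold higher number from compound 2 to compound 4 (1.78 log units; beyond the scatter)), well beyond the step at the sulfonyl sulfur (a 4.3-fold higher number from compound 2 to compound 3 (0.64 log units; beyond the scatter)). With 3-methoxyphenyl held at that carbon, 3,5-difluorophenyl in place of 3-chloro-4-methoxyphenyl on the sulfonyl sulfur leaves the number within the scatter (a 1.1-fold higher number from compound 1 to compound 4 (0.02 log units; within the scatter)), so this single pair shows no separation between those two sulfonyl groups. Nothing on hand accounts for the size of the step at the aromatic carbon.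

The compounds shown do not separate the change of substituent on this phenyl from the change of its place on the ring. They also leave open what a phenyl carrying an amine or a carboxylic acid would give at that aromatic carbon.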